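Series notes: from compound 2 toward compound 3

A few compounds are considered here, and "the series" means these few. Any claim that something is new, unique, unknown or untested is made for them only; others in the source may bear on it.

Measured so far:
compound 1 `Cc1ccc2[nH]c(C(=O)N[C@H]3CN(S(=O)(=O)c4ccnnc4)C[C@@H]3C(=O)NCCN(C)C)cc2c1` — 2 uL/min
compound 2 `Cc1ccc2[nH]c(C(=O)N[C@H]3CN(S(=O)(=O)c4ccccc4)C[C@@H]3C(=O)NC[C@@H]3CCCN3C)cc2c1` — 23 uL/min

In an ADME assay on cells (Hepatocyte, Rattus norvegicus) for metabolic stability (a lower number here means slower removal, a higher number faster removal of the compound), compound 2 gives 23 uL/min, the higher of the two numbers; compound 1 gives 2 uL/min, and the gap between them lies beyond the usual scatter. Among the compounds with values here, no single-place step connects compound 1 with compound 2, so only their two values can be set side by side.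

Compound 3 `Cc1ccc2[nH]c(C(=O)N[C@H]3CN(S(=O)(=O)c4ccccc4)C[C@@H]3C(=O)N[C@H]3CCCNC3)cc2c1` has not yet been measured. It differs from compound 2 in one place: piperidin-3-yl in place of (1-methylpyrrolidin-2-yl)methyl on an amide-type nitrogen. Neither measured compound supplies a step of this kind, so the expectation rests on the position of compound 2 alone. For this assay a modest move downward from compound 2 is expected, not clearly beyond the scatter. Compound 3 is estimated at 12 uL/min, with a range from 4 uL/min to 35 uL/min. The step this estimate implies is a 1.9-fold lower number from compound 2 to compound 3 (0.28 log units; within the scatter).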

Compound 3, intrinsic clearance in a liver preparation (reported as CLH), per the amount of preparation that the assay uses: 7 uL/min
Compound 3: the middle estimate sits 1.7-fold (0.23 log units) above what was measured; the measured number falls inside the stated range.
By their numbers in this assay, from the lowest: compound 1; then compound 3; then compound 2.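

At the amide-type nitrogen, this assay now gives the series its first single-place step: piperidin-3-yl in place of (1-methylpyrrolidin-2-yl)methyl yields a 3.3-fold lower number from compound 2 to compound 3 (0.52 log units; beyond the scatter), so the group at this position alone can shift the number beyond the scatter. The change is compound in itself, since a five-membered ring gives way to a six-membered one, the heavy-atom count differs, and the entering group carries a hydrogen-bond donor that the leaving group lacks. Nothing available explains the step.

Which of these differences carries the step stays open; a 1-methylpiperidin-3-yl group on the same nitrogen would separate the ring change from the donor change. From the compounds shown here alone, whether piperidin-3-yl gives a similar step alongside the sulfonyl substituent of compound 1 also remains unknown.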